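Working notes: cytotoxicity, compound 3 to compound 4

This account rests on a few compounds, and the source may have more. Where it says the series, first, only, none or still open, it means among the compounds named here.

Values in an ADME assay on HEK293 cells (Homo sapiens) for cytotoxicity, with a stated time of 72 h; on this read-out lower numbers stand for an effect already at smaller amounts and higher numbers for an effect only at larger amounts of compound:
compound 1 `Cc1cc(NC(=O)Nc2ccc(N(C)C)cc2)c2ccccc2n1` gives > 25000 nM, a limit of the assay.
compound 2 `Cc1cc(NC(=O)Nc2ccc(Cl)cc2)c2ccccc2n1` gives > 25000 nM, a limit of the assay.
compound 3 `Cc1cc(NC(=O)Nc2ccc(SC(F)(F)F)cc2)c2ccccc2n1` gives 13000 nM.

Among the compounds with values here, compound 3 carries the only number in the set; the other two values are limits. The steps of an at least 1.9-fold lower number from compound 1 to compound 3 (0.28 log units; that floor lies within the scatter) and an at least 1.9-fold lower number from compound 2 to compound 3 (0.28 log units; that floor lies within the scatter) reach only a floor that lies within the scatter, and a step that the two limits leave unreadable from compound 1 to compound 2, because of the limit of > 25000 nM in this assay, at which 2 of the 3 values shown sit.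

Compound 4 `Cc1cc(NC(=O)Nc2ccc(OC(F)(F)F)cc2)c2ccccc2n1` differs from compound 3 by trifluoromethoxy in place of (trifluoromethyl)sulfanyl on an aromatic carbon. Within the data shown here, no measured step bears on this exchange; the measured steps show only that compound 3 sits near two limits. The step is therefore expected at a 1.4-fold higher number from compound 3 to compound 4 (0.14 log units; within the scatter), no change beyond the scatter. Compound 4 is estimated at 18000 nM, within 7000 nM to 45000 nM.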

Compound 4, half-maximal effective concentration: 14000 nM
The estimate for compound 4 lay 1.3-fold (0.11 log units) above the measured number; the range from low to high includes it.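

The exchange of (trifluoromethyl)sulfanyl for trifluoromethoxy on this aromatic carbon, para to a large group, gives a 1.1-fold higher number from compound 3 to compound 4 (0.03 log units; within the scatter) in this assay, so the two groups cannot be told apart here. Compound 4 also gives the set a second number. Against the chloro and dimethylamino groups, an at least 1.7-fold lower number from compound 2 to compound 4 (0.25 log units; that floor lies within the scatter) and an at least 1.7-fold lower number from compound 1 to compound 4 (0.25 log units; that floor lies within the scatter) are only floors, because those two compounds sit at a limit of the assay: the limit of > 25000 nM in this assay, at which 2 of the 4 values shown sit.

Open, going by these compounds, is whether a carboxylic acid or a primary amine on this carbon would give a number rather than a limit. Also open, on these data alone, is how a longer chain at this place would read.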